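Five-membered ring swaps on the shared core

The source may hold more compounds than are shown below. What is called first, only, known or untested is meant among the compounds shown, and "the series" means these compounds.

Measured so far:
compound 1, `Nc1ccc(-c2cncc(-c3cncnc3)n2)cc1`, 77%
compound 2, `Cn1cc(-c2cncc(-c3ccc(N)cc3)n2)cn1`, 46%

Working notes. In an assay on isolated protein for inhibition of high affinity nerve growth factor receptor (Homo sapiens), with a stated time of 60 min, tested at 20 uM (on this read-out higher numbers stand for more inhibition at the one concentration tested (going by the name of the read-out) and lower numbers for less inhibition), compound 1 gives 77%, and compound 2 gives 46%. Going by the values given here, the only measured step is a number 31 percentage points lower from compound 1 to compound 2 (beyond the scatter), a 1-methyl-1H-pyrazol-4-yl in place of pyrimidin-5-yl on an aromatic carbon of the shared core. Compound 2 therefore stands lowest of the two numbers, with compound 1 the nearest and higher by that step.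

Compound 3, `Nc1ccc(-c2cncc(-c3ccsc3)n2)cc1`, is not yet measured. It differs from compound 2 by thiophen-3-yl in place of 1-methyl-1H-pyrazol-4-yl on an aromatic carbon. The step from compound 1 to compound 2 bears on this, since it changes the same group at the same place, and it was large; yet it gives no direction for a thiophen-3-yl, which is a third group with no measured partner. Among the compounds with values here, with only one step at this position the estimate is wide and centred near compound 2. Compound 3 is expected to give 45% in this assay, within 15% to 75%. The expected step is a number 1 percentage points lower from compound 2 to compound 3 (within the scatter), which is not beyond the scatter.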

Compound 3, a percentage reported as inhibition, at one concentration (the size of the read-out at that concentration, not a potency): 17%
Beside the measured number, compound 3's estimate is 28 percentage points above it; the range from low to high includes it.
By their numbers in this assay, from the lowest: compound 3; then compound 2; then compound 1.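

In this assay, thiophen-3-yl in place of 1-methyl-1H-pyrazol-4-yl gives a number 29 percentage points lower from compound 2 to compound 3 (beyond the scatter) on the shared core, so two five-membered aromatic rings at this place are not interchangeable. Set against pyrimidin-5-yl, the same group gives a number 60 percentage points lower from compound 1 to compound 3 (beyond the scatter) in this series, and together with a number 31 percentage points lower from compound 1 to compound 2 (beyond the scatter) this places the three groups in one order, with each step beyond the scatter and thiophen-3-yl, the only one of the three rings without a ring nitrogen, at the bottom. That order rests on these three compounds alone, and no available measurement accounts for it.

Open, going by these compounds, is whether a ring nitrogen is what separates these groups, which a pyridin-3-yl or a thiazol-5-yl at the same place could test against the pyrimidin-5-yl and thiophen-3-yl pair, and whether a group without a ring, such as an amine or a carboxylic acid, would hold any of the inhibition. Each number also comes from one tested concentration, so the order of the three compounds says nothing yet about their potency.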